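Aryl hydrazones on the shared core: dosing limits

A few compounds are considered here, and "the series" means these few. Any claim that something is new, unique, unknown or untested is made for them only; others in the source may bear on it.

Compound 1 `CC1CC/C(=N\Nc2ccc(F)cc2)c2ncc(C(=O)O)c(=O)n21`, compound 2 `CC1CC/C(=N\Nc2cccc(Cl)c2)c2ncc(C(=O)O)c(=O)n21` and compound 3 `CC1CC/C(=N\Nc2ccccc2I)c2ncc(C(=O)O)c(=O)n21` share one core and differ only in the aryl group on the amine nitrogen. In a functional assay on the whole organism for inhibition, with Rattus norvegicus as the target (a higher number here means that more compound is needed for the effect, a lower number that less compound is needed), compound 1 gives only a limit, > 1000 umol/kg. Compound 2 likewise gives only a limit, > 100 umol/kg. Compound 3 gives only a limit, > 1000 umol/kg. Compound 3 thus stands at the limit of > 1000 umol/kg in this assay, at which 2 of the 3 values shown sit, shared with compound 1, whereas compound 2 stands at the limit of > 100 umol/kg in this assay, at which 1 of the 3 values shown sits. The steps a step that the two limits leave unreadable from compound 1 to compound 2, a step that the two limits leave unreadable from compound 1 to compound 3 and a step that the two limits leave unreadable from compound 2 to compound 3 are all unreadable, so no step size within the series is known. Compound 4 `CC(=O)c1ccccc1N/N=C1\CCC(C)n2c1ncc(C(=O)O)c2=O` carries acetyl in place of iodo on an aromatic carbon. With no readable step, no direction is expected and a further limit is the likeliest outcome. The expected step of a number no higher from compound 3 to compound 4 (the limit leaves the size open) is estimated near zero. Compound 4 is estimated at 1000 umol/kg, within 100 umol/kg to 3000 umol/kg.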

Compound 4, dose for 50% inhibition: > 1000 umol/kg
Compound 4 gave a limit, no number; the forecaster's own chance of this, stated with the estimate: 80%; the middle value sits exactly at the limit.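

Compound 4 gives only a limit, > 1000 umol/kg. Compound 3 is also a limit, so the step to compound 4 cannot be read. The compounds shown leave open whether any of these aryl groups gives an actual number in this assay.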